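Swapping Sulfo for Fluoro on a Weak Inhibitor

A few compounds are considered here, and "the series" means these few. Any claim that something is new, unique, unknown or untested is made for them only; others in the source may bear on it.

Compound 1 `O=C(O)c1cnc2cc(S(=O)(=O)O)ccc2c1O`: in an assay on isolated protein with malate dehydrogenase, mitochondrial (Sus scrofa) as the target (a higher number here means a weaker inhibitor, a lower number a stronger inhibitor), compound 1 gives 2140000 nM
Compound 2 `O=C(O)c1cnc2cc(OCc3ccc(Cl)c(Cl)c3)ccc2c1O`: in this assay compound 2 gives 4790 nM

Compound 1 stands at the highest of the two numbers, making it the weaker inhibitor; compound 2 gives a far lower number, a gap well beyond the scatter. Compound 3 `O=C(O)c1cnc2cc(F)ccc2c1O` has not been measured. It differs from compound 1 by fluoro in place of sulfo on an aromatic carbon. Among the measured compounds shown here, no measured pair shows this change, so the direction is uncertain; a drop in number, beyond the scatter, is expected, with the step from compound 1 to compound 3 estimated at a 7.1-fold lower number from compound 1 to compound 3 (0.85 log units; beyond the scatter). For compound 3 the expected value is 300000 nM, within a range from 40000 nM to 2500000 nM.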

Compound 3, half-maximal inhibitory concentration: 10500000 nM
Beside the measured number, compound 3's estimate is 35-fold (1.54 log units) below it, and the stated range ends below it.
By their numbers in this assay, from the lowest: compound 2; then compound 1; then compound 3.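

Putting fluoro in place of sulfo on this aromatic carbon does not give a stronger inhibitor in this assay: the number rises, with a 4.9-fold higher number from compound 1 to compound 3 (0.69 log units; beyond the scatter). On this core, then, the smaller group with one heavy atom instead of four gives the weaker inhibitor of the pair. Nothing available here explains why the number rises.

Going by these compounds, what remains open is how an amine or a methoxy group on this same carbon would compare with sulfo and fluoro. A single step also cannot show whether the same swap would raise the number on a different core.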